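Ring Size on the Pyridazinone Nitrogen and Weak Inhibition

A few compounds are considered here, and "the series" means these few. Any claim that something is new, unique, unknown or untested is made for them only; others in the source may bear on it.

Among the compounds with values here, compound 2 `O=c1cc(-c2ccccc2)c(-c2ccccc2)nn1C1CCCC1` gives 119000 nM in an assay on microsomes from liver for inhibition of sterol O-acyltransferase 1 (Rattus norvegicus) (a higher number here means a weaker inhibitor, a lower number a stronger inhibitor), the higher of the two numbers so far; compound 1 `CCCCCCCCCn1nc(-c2ccccc2)c(-c2ccccc2)cc1=O` gives 85000 nM, and a 1.4-fold higher number from compound 1 to compound 2 (0.15 log units; within the scatter). Compound 3 `O=c1cc(-c2ccccc2)c(-c2ccccc2)nn1C1CCCCC1` carries one change, (cyclohexyl in place of cyclopentyl on an aromatic nitrogen). Within the data shown here, only one measured step bears on it: the change from nonyl to cyclopentyl stayed within the scatter, so a shift in this assay of at most the same size is expected. Compound 3 is therefore estimated at 100000 nM, between 40000 nM and 300000 nM, which would mean a 1.2-fold lower number from compound 2 to compound 3 (0.08 log units; within the scatter).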

Compound 3, half-maximal inhibitory concentration: > 300000 nM
Compound 3 gave a limit, no number; the forecaster's own chance of this, stated with the estimate: 15%; at least 3.0-fold (0.47 log units) between middle value and limit.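

Compound 3 gives no number, only a limit: the limit of > 300000 nM in this assay, at which 1 of the 3 values shown sits.

Nonyl and cyclopentyl on the aromatic nitrogen could not be told apart in this assay, but this position does respond to its group: cyclohexyl in place of cyclopentyl gives an at least 2.5-fold higher number from compound 2 to compound 3 (0.40 log units; beyond the scatter), and cyclohexyl in place of nonyl gives an at least 3.5-fold higher number from compound 1 to compound 3 (0.54 log units; beyond the scatter). Changing a five-membered ring to a six-membered one is thus enough to weaken inhibition.

Going by these compounds, the true size of both steps stays open, for a limit sets only a floor. On these data alone, whether a cyclopropyl ring, an amine or a carboxylic acid on this nitrogen would give a lower number also stays open.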